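From methoxycarbonyl to carbamoyl on the shared core

This account rests on a few compounds, and the source may have more. Where it says the series, first, only, none or still open, it means among the compounds named here.

Going by the values given here, in a physicochemical assay for solubility, at pH 7.4 (on this read-out lower numbers stand for lower solubility and higher numbers for higher solubility), compound 2 `COC(=O)c1ccc(NC(=O)Nc2cc(C)nc3ccccc23)cc1` gives 1200 nM as the lower of the two numbers so far, while compound 1 `Cc1cc(NC(=O)Nc2ccc(F)cc2)c2ccccc2n1` gives 3700 nM as the higher. Compound 3 `Cc1cc(NC(=O)Nc2ccc(C(N)=O)cc2)c2ccccc2n1` has amino in place of methoxy on a carbonyl carbon. Among the compounds with values here, the one measured step that bears on this is a 3.1-fold lower number from compound 1 to compound 2 (0.49 log units; beyond the scatter) with methoxycarbonyl in place of fluoro on an aromatic carbon, a modest step beyond the scatter. It is a different swap and gives no direction, so the expected change in this assay is small: the estimate is a 1.3-fold higher number from compound 2 to compound 3 (0.10 log units; within the scatter) and no shift beyond the scatter is expected. Compound 3 is estimated at 1500 nM with an expected range of 500 nM to 4500 nM on this read-out.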

Compound 3, solubility: 900 nM
Beside the measured number, compound 3's estimate is 1.7-fold (0.22 log units) above it; measured number inside the range.
By their numbers in this assay, from the lowest: compounds 3 and 2 (each within the scatter of the next); then compound 1.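

In this assay, amino in place of methoxy on a carbonyl carbon gives a 1.3-fold lower number from compound 2 to compound 3 (0.12 log units; within the scatter) and so separates compound 3 from compound 2 by no more than the usual scatter. Carbamoyl in place of fluoro on an aromatic carbon gives a 4.1-fold lower number from compound 1 to compound 3 (0.61 log units; beyond the scatter) and so puts a second carbonyl-bearing group lower than fluoro, in the same direction as methoxycarbonyl. Nothing shown explains why these numbers fall as they do. Going by these compounds, how a carboxylic acid or a methylamino group at this place would read on the shared core stays open.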